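A few compounds are considered here, and "the series" means these few. Any claim that something is new, unique, unknown or untested is made for them only; others in the source may bear on it.

Compound 1 `O=S(=O)(/C=C/c1ccc(Cl)cc1Cl)Cc1ccc(Nc2ncnc3ccccc23)cc1`: 5000 nM
Compound 2 `O=S(=O)(/C=C/c1ccc(Cl)cc1Cl)Cc1ccc(Nc2ncnc3ccc(Br)cc23)cc1`: > 100000 nM (a limit, not a number)

In a functional assay on NCI/ADR-RES cells (Homo sapiens) for inhibition (a lower number here means a stronger inhibitor of growth, a higher number a weaker inhibitor of growth), compound 2 gives only a limit, > 100000 nM. Compound 3 `O=S(=O)(/C=C/c1ccc(F)cc1F)Cc1ccc(Nc2ncnc3ccc(Br)cc23)cc1` differs from it by 2,4-difluorophenyl in place of 2,4-dichlorophenyl on a double-bonded chain carbon bound to a double-bonded chain carbon, with 2,4-difluorophenyl in place of 2,4-dichlorophenyl. For the measured compounds named here, no measured step covers this exchange. Going by the values given here, compound 3 keeps the bromo of the only measured step, an at least 20-fold higher number from compound 1 to compound 2 (1.30 log units; beyond the scatter), a large change, so it is expected to remain a weak inhibitor of growth, with at most a modest move towards a lower number. The expected change is an at least 1.6-fold lower number from compound 2 to compound 3 (0.22 log units; that floor lies within the scatter). Compound 3 is estimated at 60000 nM, within a range of 10000 nM to 200000 nM.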

Compound 3, concentration for 50% growth inhibition: 100000 nM
For compound 3 the middle estimate is 1.7-fold (0.22 log units) below the measured one; the measured number falls inside the stated range.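

In this assay compound 3 gives 100000 nM, so a compound keeping the bromo now has a number rather than a limit, with 2,4-difluorophenyl in place of 2,4-dichlorophenyl on a double-bonded chain carbon bound to a double-bonded chain carbon. The exchange gives a number no higher from compound 2 to compound 3 (the limit leaves the size open). The size of this step cannot be read because compound 2 gives only a limit: the limit of > 100000 nM in this assay, at which 1 of the 3 values shown sits.

The compounds shown leave open what this exchange does on compound 1, which has no bromo. They also leave open whether an amine or a carboxylic acid on the same chain carbon, in place of the halogenated phenyl, would give a lower number.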